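Shortening the alkylamine chain on the cyanopyridinone core

A few compounds are considered here, and "the series" means these few. Any claim that something is new, unique, unknown or untested is made for them only; others in the source may bear on it.

Three measured compounds share the same core and differ only in the substituent on the ring nitrogen-bound position. In an in vitro functional assay on cells for antagonist activity at metabotropic glutamate receptor 1 (Rattus norvegicus), read by inositol phosphate accumulation (on this read-out higher numbers stand for weaker inhibition and lower numbers for stronger inhibition), compound 1 `CC1(C)CC(=O)c2cc(C#N)c(N3CCc4ccccc4C3)nc2C1` gives 1500 nM, compound 3 `CC1(C)CC(=O)c2cc(C#N)c(N3CC=C(c4ccc(F)cc4)CC3)nc2C1` gives 110 nM, and compound 2 `CCCCCCNc1nc2c(cc1C#N)C(=O)CC(C)(C)C2` gives 2600 nM. Compound 2 has the highest number of the three; its nearest neighbour is compound 1, and the two lie within the scatter of each other, while compound 3 sits far lower, well beyond the scatter.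

Compound 4 `CCCNc1nc2c(cc1C#N)C(=O)CC(C)(C)C2` is not yet measured. It is derived from compound 2 by one change: hydrogen in place of propyl on a saturated chain carbon, three bonds along the chain from a nitrogen on an aromatic ring. Within the data shown here, no measured pair shows this change, so the size of the step is open. On the numbers shown, a modest move toward weaker inhibition is expected, since the only compound with a small substituent, compound 2, already gives 2600 nM; the step from compound 2 to compound 4 in this assay is estimated at a 1.9-fold higher number from compound 2 to compound 4 (0.28 log units; within the scatter), though a result within the scatter would not be surprising. For compound 4 the expected value in this assay is 5000 nM, with a range of 1500 nM to 16000 nM.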

Compound 4, half-maximal inhibitory concentration: 2300 nM
For compound 4 the middle estimate is 2.2-fold (0.34 log units) above the measured one; measured number inside the range.
By their numbers in this assay, from the lowest: compound 3; then compounds 1, 4 and 2 (each within the scatter of the next).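

In this assay, hydrogen in place of propyl on a saturated chain carbon, three bonds along the chain from a nitrogen on an aromatic ring, gives a 1.1-fold lower number from compound 2 to compound 4 (0.05 log units; within the scatter). Among these compounds, this is the first step that differs in one place, and it shows that hexyl and propyl cannot be told apart at this position on this read-out, so the outer part of the hexyl chain carries no effect beyond the scatter. No independent data bearing on this result are available.

Still open, as far as these compounds go, is whether the same holds for a chain shorter than propyl, such as ethyl or methyl, or whether the numbers shift there. Also open, from the compounds shown here alone, is how a chain ending in an amine or a carboxylic acid, or a branched chain such as isopropyl, would read at this position.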